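Swapping Bromomethyl for Tetrafluoroethyl on the Chain

The source may report more compounds than this note shows. Statements on the series, on what has been measured and on what is new or still open speak of the compounds shown alone.

Compound 3 `C[C@@H](NC(=O)OCCBr)c1nc2ccc(F)cc2s1` stands second highest of the three compounds measured in a physicochemical assay for lipophilicity, using the shake flask method, measured as octanol-water partition, with a stated time of 15 min (a lower number here means a more polar compound, a higher number a more lipophilic compound), where compound 3 gives 3.17. Its nearest neighbour is compound 1 `COC(=O)N[C@H](C)c1nc2ccc(F)cc2s1`, which in this assay gives 2.5, and the furthest is compound 2 `CCOC(=O)N[C@H](C)c1nc2ccc(F)cc2s1`, which gives 4.2. Compound 4 `C[C@@H](NC(=O)OCC(F)(F)C(F)F)c1nc2ccc(F)cc2s1` differs from compound 3 by 1,1,2,2-tetrafluoroethyl in place of bromomethyl on a saturated chain carbon bound to an oxygen next to a carbonyl group. The chain steps measured so far were a number 0.67 log units higher from compound 1 to compound 3 (beyond the scatter), a number 1.70 log units higher from compound 1 to compound 2 (beyond the scatter) and a number 1.03 log units lower from compound 2 to compound 3 (beyond the scatter); none of them puts fluorine on the chain or exchanges one bromine-bearing group for a fluorine-bearing one, so they bound the change only loosely. The step expected here is a number 0.23 log units higher from compound 3 to compound 4 (within the scatter), within the scatter. In this assay compound 4 is estimated at 3.4, with a range from 2.8 to 4.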

Compound 4, partition coefficient: 2.92
The estimate for compound 4 lay 0.48 log units above the measured number; low and high end bracket the measured number.
By their numbers in this assay, from the lowest: compound 1; then compounds 4 and 3 (each within the scatter of the next); then compound 2.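

In this assay the exchange of bromomethyl for 1,1,2,2-tetrafluoroethyl gives a number 0.25 log units lower from compound 3 to compound 4 (within the scatter) and so cannot be told from no change at this place, although the entering group holds more heavy atoms. Against methyl the same group gives a number 1.28 log units lower from compound 2 to compound 4 (beyond the scatter) and against hydrogen it gives a number 0.42 log units higher from compound 1 to compound 4 (beyond the scatter) so the number here does not simply follow the size of the group. No evidence at hand bears on why these groups fall as they do. The compounds shown leave open how trifluoromethyl, a longer unfluorinated chain or an amine would read at this place.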